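The source may report more compounds than this note shows. Statements on the series, on what has been measured and on what is new or still open speak of the compounds shown alone.

Measured compounds:
compound 1 `CCCCS(=O)(=O)Nc1cc(-c2ccc3c(c2)N(CCCN(CC)CC)C(=O)CO3)cnc1OC` — 17600 nM
compound 2 `COc1ncc(-c2ccc3c(c2)N=C(N2CCN(CCCO)CC2)CO3)cc1NS(=O)(=O)c1ccc(F)cc1F` — 4970 nM

In a functional assay on SNU-638 cells (Homo sapiens) for antiproliferative activity, read by sulforhodamine B assay, with a stated time of 72 h (a higher number here means a weaker inhibitor, a lower number a stronger inhibitor), compound 1 gives 17600 nM and compound 2 gives 4970 nM, so compound 2 carries the lower of the two numbers, a gap beyond the scatter. Compound 3 `CCOC(=O)CN1CCN(C2=Nc3cc(-c4cnc(OC)c(NS(=O)(=O)c5ccc(F)cc5F)c4)ccc3OC2)CC1` differs from compound 2 by ethoxycarbonyl in place of 2-hydroxyethyl on a saturated chain carbon bound to an amine nitrogen in a ring. Within the data shown here, no step between measured compounds covers this change, so nothing here fixes its size; the step from compound 2 to compound 3 is expected to be small, a 1.1-fold higher number from compound 2 to compound 3 (0.04 log units; within the scatter), within or near the scatter in either direction. Compound 3 is therefore estimated at 5500 nM, with a range from 1800 nM to 17000 nM.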

Compound 3, half-maximal inhibitory concentration: 21400 nM
For compound 3 the middle estimate is 3.9-fold (0.59 log units) below the measured one, outside the stated range (above it).
By their numbers in this assay, from the lowest: compound 2; then compounds 1 and 3 (each within the scatter of the next).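

At this position, on a saturated chain carbon bound to an amine nitrogen in a ring, the group carried does matter in this assay: ethoxycarbonyl in place of 2-hydroxyethyl gives a 4.3-fold higher number from compound 2 to compound 3 (0.63 log units; beyond the scatter). The entering group has no hydrogen-bond donor, whereas the leaving group has one. No measurement shown explains the step. The compounds shown leave open whether the hydroxyl or the ester drives this difference, and how a carboxylic acid, a primary amide or a longer hydroxyalkyl chain would read at the same place.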